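Hydrazone series: thiophene to thiadiazole at the carbonyl

The source may report more compounds than this note shows. Statements on the series, on what has been measured and on what is new or still open speak of the compounds shown alone.

Measured compounds:
compound 1 `O=C(N/N=C/C1=Cc2ccccc2OC1c1ccccc1)c1ccc(Cl)cc1` — 13200 nM
compound 2 `O=C(N/N=C/C1=Cc2ccccc2OC1c1ccccc1)c1cccs1` — "not determined" (no result reported)

In a toxicity assay on HEK-293T cells (Homo sapiens) for cytotoxicity, read by MTT assay, with a stated time of 72 h (a lower number here means a stronger inhibitor, a higher number a weaker inhibitor), compound 1 gives 13200 nM. Compound 2 carries no number in this assay, so its standing cannot be placed against compound 1. Compound 3 `Cc1nnsc1C(=O)N/N=C/C1=Cc2ccccc2OC1c1ccccc1` differs from compound 2 in one place: 4-methyl-1,2,3-thiadiazol-5-yl in place of thiophen-2-yl on a carbonyl carbon. Going by the values given here, no step between measured compounds exists to calibrate this change, and the shared core is otherwise unchanged; no move beyond the scatter is expected in this assay. Compound 3 is estimated at 15000 nM, with a range from 5000 nM to 50000 nM, resting only on compound 1 at 13200 nM.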

Compound 3, half-maximal inhibitory concentration: 30200 nM
The estimate for compound 3 lay 2.0-fold (0.30 log units) below the measured number; the range from low to high includes it.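

Going by these compounds alone, on a carbonyl carbon, 4-methyl-1,2,3-thiadiazol-5-yl in place of 4-chlorophenyl gives the first readable step in this assay: a 2.3-fold higher number from compound 1 to compound 3 (0.36 log units; beyond the scatter), which is modest but beyond the scatter. The group at this position can therefore shift the reading, here toward weaker inhibition. No measurement at hand explains the shift.

The step from compound 2 to compound 3 cannot be read, so the change from thiophen-2-yl to the thiadiazole remains unplaced. Also open, from the compounds shown here alone, is how a pyridin-3-yl group or an unmethylated 1,2,3-thiadiazol-5-yl group would read at this position.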